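This account rests on a few compounds, and the source may have more. Where it says the series, first, only, none or still open, it means among the compounds named here.

Series notes. The shared core carries a benzylic amine on one side and a hydroxymethyl-bearing phenyl on the other. Compound 1 `Nc1nc(NCc2ccc(Cl)cc2)nc(-c2ccccc2CO)n1` gives 5.22 in a functional assay on cells for positive allosteric modulation of G-protein coupled receptor 68 (Homo sapiens), read by a luciferase reporter and cAMP accumulation, with a stated time of 30 min, at pH 6.8 and pH 8.3, in the presence of a further agent that is not named here; on this read-out lower numbers stand for lower potency and higher numbers for higher potency (the scale is a negative logarithm). Among the compounds with values here, compound 2 `Cc1ccc(CNc2nc(N)nc(-c3ccccc3CO)n2)cc1` gives 4.38 in this assay, the lowest of the two numbers so far; the only step measured, a number 0.84 log units lower from compound 1 to compound 2 (beyond the scatter), is beyond the scatter.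

The next compound, compound 3 `COc1ccccc1CNc1nc(N)nc(-c2ccccc2CO)n1`, is not yet measured. Its change from compound 2 is 2-methoxyphenyl in place of 4-methylphenyl on a saturated chain carbon bound to a nitrogen on an aromatic ring. Within the data shown here, no measured step involves the same change: the step from compound 1 to compound 2 swaps chloro for methyl on the aromatic carbon and says nothing about a methoxy group or about moving the substituent. It only shows that the benzyl substituent can shift the number by a modest amount. The expectation for compound 3 is therefore centred close to compound 2, with a wide range, and the step of a number 0.32 log units higher from compound 2 to compound 3 (beyond the scatter) is expected to be small. Compound 3 is estimated at 4.7, between 4.1 and 5.4.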

Compound 3, negative logarithm of the antagonist equilibrium constant: 3.99
For compound 3 the middle estimate is 0.71 log units above the measured one; measured number below the stated range.
By their numbers in this assay, from the lowest: compound 3; then compound 2; then compound 1.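

On a saturated chain carbon bound to a nitrogen on an aromatic ring, the steps of a number 0.39 log units lower from compound 2 to compound 3 (beyond the scatter) and a number 1.23 log units lower from compound 1 to compound 3 (beyond the scatter) put 2-methoxyphenyl lowest of the three benzylic substituents in this assay for this series. The position therefore tolerates less than the swap of chloro for methyl alone had shown, and the number falls further even though the entering group brings a hydrogen-bond acceptor that 4-methylphenyl and 4-chlorophenyl lack. No measurement at hand bears on why the number falls here.

The change from 4-methylphenyl to 2-methoxyphenyl alters both the substituent and its place on the phenyl ring, and the compounds shown cannot separate the two. Also open, on these data alone, is how this position would respond to a phenyl ring carrying an amine or a carboxylic acid, or to a longer chain.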